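This account rests on a few compounds, and the source may have more. Where it says the series, first, only, none or still open, it means among the compounds named here.

Two compounds anchor this series in a physicochemical assay for lipophilicity, at pH 7.4; a higher number here means a more lipophilic compound, a lower number a more polar compound. Compound 1 `O=C(NC1CC1)C1CCN(c2cncnc2-c2ccccc2)CC1` gives 1.8 and compound 2 `CCNC(=O)C1CCN(c2cncnc2-c2ccccc2)CC1` gives 1.8, which leaves compound 2 level with compound 1. Compound 3 `O=C(Nc1ccccc1)C1CCN(c2cncnc2-c2ccccc2)CC1` keeps the shared core and carries phenyl in place of ethyl on an amide-type nitrogen. Within the data shown here, only one measured step bears on this change. That step, no change at the digits printed from compound 1 to compound 2 (within the scatter), put ethyl in place of cyclopropyl and stayed within the scatter. Among the measured compounds shown here, it is a weak guide here, as no measured compound has an aromatic ring entering on this nitrogen. The expectation therefore rests on the structural change itself, with phenyl entering where ethyl leaves. An upward move in this assay is expected, estimated as a number 0.90 log units higher from compound 2 to compound 3 (beyond the scatter). For compound 3 the expected value is 2.7, with an estimated range from 2.2 to 3.2.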

Compound 3, distribution coefficient: 2.7
For compound 3 middle estimate and measured number coincide at the digits printed; measured number inside the range.
By their numbers in this assay, from the lowest: compounds 1 and 2 (each within the scatter of the next); then compound 3.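

In this assay, the amide-type nitrogen had shown nothing when cyclopropyl gave way to ethyl, yet it responds once phenyl enters. Phenyl in place of ethyl gives a number 0.90 log units higher from compound 2 to compound 3 (beyond the scatter), and phenyl in place of cyclopropyl gives a number 0.90 log units higher from compound 1 to compound 3 (beyond the scatter). The position is therefore not indifferent to every change of group, and the two steps have the same size from either starting group.

The compounds shown cannot separate the aromatic ring from the larger number of carbons, a question that cyclohexyl, hexyl or a pyridyl ring on this nitrogen would bear on. Nothing available here gives an explanation for the rise in this read-out.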